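Replacing the fused ring on the sulfur: compound 3 to compound 4

This account rests on a few compounds, and the source may have more. Where it says the series, first, only, none or still open, it means among the compounds named here.

Measured in a functional assay on HCT-116 cells (Homo sapiens) for cytotoxicity, read by MTT assay; on this read-out lower numbers stand for stronger inhibition and higher numbers for weaker inhibition:
compound 1 `CSc1nc(NCc2ccc(C(=O)Nc3ccccc3N)cc2)n[nH]1` at 600 nM
compound 2 `Nc1ccccc1NC(=O)c1ccc(CSc2nc3ccccc3[nH]2)cc1` at 300 nM
compound 3 `Nc1ccccc1NC(=O)c1ccc(CSc2nc3ccccc3s2)cc1` at 800 nM

Compound 3 stands at 800 nM, compound 1 at 600 nM and compound 2 at 300 nM in the same read-out. The gap between compound 3 and compound 1 lies within the scatter, and the gap between compound 3 and compound 2 lies beyond it. The next structure is compound 4 `Cn1ccnc1SCc1ccc(C(=O)Nc2ccccc2N)cc1`, with 1-methyl-1H-imidazol-2-yl in place of 1,3-benzothiazol-2-yl on a sulfur. For the measured compounds named here, only one measured step bears on this place (a 2.7-fold higher number from compound 2 to compound 3 (0.43 log units; beyond the scatter)), and it is modest. That step keeps a fused ring on the sulfur, whereas compound 4 has none, so the data do not directly test this change. Going by the values given here, no measured compound carries 1-methyl-1H-imidazol-2-yl, and the direction of any shift remains open. The step expected in this assay is a 1.1-fold higher number from compound 3 to compound 4 (0.05 log units; within the scatter) and thus none beyond the scatter. Compound 4 is estimated at 900 nM within an expected range of 300 nM to 2500 nM in this read-out.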

Compound 4, half-maximal inhibitory concentration: 5000 nM
Estimate against measurement, compound 4: 5.6-fold (0.74 log units) below; measured number above the stated range.
By their numbers in this assay, from the lowest: compounds 2, 1 and 3 (each within the scatter of the next, the first and the last beyond it); then compound 4.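

In this assay, 1-methyl-1H-imidazol-2-yl on the sulfur gives a 6.3-fold higher number from compound 3 to compound 4 (0.80 log units; beyond the scatter) and a 17-fold higher number from compound 2 to compound 4 (1.22 log units; beyond the scatter), whereas the exchange between the two fused groups gave only a 2.7-fold higher number from compound 2 to compound 3 (0.43 log units; beyond the scatter), so this place tolerates that exchange better than the loss of the fused system. (1-Methyl-1H-imidazol-2-yl)sulfanyl in place of (5-(methylsulfanyl)-1H-1,2,4-triazol-3-yl)amino on a saturated chain carbon bound to an aromatic carbon gives an 8.3-fold higher number from compound 1 to compound 4 (0.92 log units; beyond the scatter), so a single five-membered aromatic ring does not alone set the higher number. No evidence on the cause of these steps is available.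

The compounds shown do not separate the loss of the six-membered aromatic ring from the entry of the methyl on nitrogen. 1H-imidazol-2-yl or 1-methyl-1H-benzimidazol-2-yl on the sulfur would bear on that question.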